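The source may report more compounds than this note shows. Statements on the series, on what has been measured and on what is new or still open speak of the compounds shown alone.

Compound 1 `CNC(=O)c1cc(-c2ccc(F)cc2F)ccc1OC(=O)c1ccccc1`: 68.9%
Compound 2 `O=C(Oc1ccc(-c2ccc(F)cc2F)cc1C(=O)Nc1ccccc1)c1ccccc1`: 19.8%
Compound 3 `Cc1ccccc1NC(=O)c1cc(-c2ccc(F)cc2F)ccc1OC(=O)c1ccccc1`: 21.4%

In a functional assay on the whole organism (Ear) for inhibition, with Mus musculus as the target, at a dose of 40 mg/kg by the oral route (a higher number here means more inhibition at the dose given (going by the name of the read-out), a lower number less inhibition), compound 3 stands second highest of the three numbers; compound 2 lies within the scatter of it, while compound 1 sits well above it, as the step of a number 47.5 percentage points lower from compound 1 to compound 3 (beyond the scatter) shows. Compound 4 `CCN(CC)C(=O)c1cc(-c2ccc(F)cc2F)ccc1OC(=O)c1ccccc1` differs from compound 3 in one place: diethylamino in place of (2-methylphenyl)amino on a carbonyl carbon. For the measured compounds named here, no measured step makes exactly this change. Going by the values given here, the steps that bear on it are a number 49.1 percentage points lower from compound 1 to compound 2 (beyond the scatter) and a number 47.5 percentage points lower from compound 1 to compound 3 (beyond the scatter), both large, showing that a methyl on the amide-type nitrogen gave a far higher number than a phenyl or a 2-methylphenyl. Among the compounds with values here, with the ring leaving and a small alkyl group entering, a rise beyond the scatter is expected, though the loss of the hydrogen-bond donor has no measured counterpart, which tempers it. The step from compound 3 is therefore expected to be a number 20.6 percentage points higher from compound 3 to compound 4 (beyond the scatter). Compound 4 is estimated at 42%, within 18% to 66%.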

Compound 4, a percentage reported as inhibition, in the whole organism at one dose (the size of the read-out at that dose, not a potency): 65.2%
Estimate against measurement, compound 4: 23.2 percentage points below, within the range that was stated.
By their numbers in this assay, from the lowest: compounds 2 and 3 (each within the scatter of the next); then compounds 4 and 1 (each within the scatter of the next).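

Replacing the aryl amines on the carbonyl carbon with diethylamino gives a number 43.8 percentage points higher from compound 3 to compound 4 (beyond the scatter) and a number 45.4 percentage points higher from compound 2 to compound 4 (beyond the scatter) in this assay. The step of a number 3.7 percentage points lower from compound 1 to compound 4 (within the scatter) shows that, in this pair, the amide hydrogen is not needed for a high number, since diethylamino has no hydrogen-bond donor and methylamino has one. Nothing available explains why these two alkyl amides stand apart from the two aryl amides.

Going by these compounds, it remains open whether a ring amine such as piperidine or morpholine would hold this level on the carbonyl carbon. The same is open for a longer chain such as dibutylamino.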